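Three piperazine analogues and a difluoro partner

The compounds below may be only part of what the source reports. "The series", "measured", "known", "first", "only" and "open" are said of these compounds alone.

Measured compounds:
compound 1 `Nc1scc(CN2CCN(c3ccc(Cl)cc3Cl)CC2)c1C(=O)c1ccc(Cl)cc1` — 2%
compound 2 `Nc1scc(CN2CCN(C3CCCCCC3)CC2)c1C(=O)c1ccc(Cl)cc1` — 2.9%
compound 3 `Nc1scc(CN2CCN(c3ccccc3F)CC2)c1C(=O)c1ccc(Cl)cc1` — 2.1%

In a functional assay on CHO cells with adenosine receptor A1 (Homo sapiens) as the target, read by cAMP accumulation and immunoassay, with a stated time of 6 min, tested at 0.01 uM (on this read-out higher numbers stand for a weaker effect at the one concentration tested and lower numbers for a stronger effect), compound 1 gives 2%, compound 2 gives 2.9% and compound 3 gives 2.1%. Compound 3 stands second highest of the three numbers, but its neighbours lie close: a number 0.1 percentage points higher from compound 1 to compound 3 (within the scatter) and a number 0.8 percentage points lower from compound 2 to compound 3 (within the scatter) are both within the scatter, as is a number 0.9 percentage points higher from compound 1 to compound 2 (within the scatter). Swapping the group on the amine nitrogen in the ring, whether aryl for aryl or aryl for cycloheptyl, has thus left the read-out essentially unchanged across these three compounds.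

Compound 4 `Nc1scc(CN2CCN(c3c(F)cccc3F)CC2)c1C(=O)c1ccc(Cl)cc1` differs from compound 3 by fluoro in place of hydrogen on an aromatic carbon, the same change read one bond further out being 2-fluorophenyl to 2,6-difluorophenyl. Going by the values given here, no measured pair shows exactly this change; the pairs that do bear on it, all touching the group on that same nitrogen, stayed within the scatter. On that basis no step beyond the scatter is expected, and the step of a number 0.4 percentage points higher from compound 3 to compound 4 (within the scatter) is estimated accordingly. For compound 4 the expected value in this assay is 2.5%, in the range 0.5% to 8%.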

Compound 4, a percentage reported as activity, at one concentration (the size of the read-out at that concentration, not a potency): -12%
The estimate for compound 4 lay 14.5 percentage points above the measured number; measured number outside the range, below it.
By their numbers in this assay, from the lowest: compound 4; then compounds 1, 3 and 2 (each within the scatter of the next).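

In this assay, going by these compounds alone, fluoro in place of hydrogen on an aromatic carbon ortho to a large group gives a number 14.1 percentage points lower from compound 3 to compound 4 (beyond the scatter), the first step on this nitrogen substituent that lies beyond the scatter. The 2,6-difluorophenyl group also separates compound 4 from the other two analogues, with a number 14.9 percentage points lower from compound 2 to compound 4 (beyond the scatter) and a number 14 percentage points lower from compound 1 to compound 4 (beyond the scatter), so the read-out does respond to a change in this group, although the earlier swaps on the same nitrogen left it within the scatter. Nothing available explains why this single added fluoro has that effect.

The compounds shown leave open whether a chloro or a methoxy group on that same aromatic carbon would shift the number as fluoro does. They also leave open whether the step would hold at other concentrations, as the read-out comes from a single one.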